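Extending Compound 2 with a Second Chlorophenyl Ring

The compounds below may be only part of what the source reports. "The series", "measured", "known", "first", "only" and "open" are said of these compounds alone.

Measured so far:
compound 1 `CS(=O)(=O)c1cccc(-c2ccc(-n3cc(-c4ccccc4)nn3)cc2)c1` — in a functional assay on MCF7 cells (Homo sapiens) for inhibition, read by resazurin assay, with a stated time of 72 h (on this read-out higher numbers stand for weaker inhibition and lower numbers for stronger inhibition), compound 1 gives < 50000 nM, which is a limit of the assay rather than a number.
compound 2 `Clc1ccccc1-c1ccn2ncnc2n1` — in this assay compound 2 gives > 100000 nM, again a limit of the assay.
compound 3 `COc1ccc(F)cc1-c1ccn2ncnc2n1` — in this assay compound 3 gives > 100000 nM, also a limit of the assay.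

Compound 2 therefore stands at the limit of > 100000 nM in this assay, at which 2 of the 3 values shown sit. Compound 1 stands at the limit of < 50000 nM in this assay, at which 1 of the 3 values shown sits. Within the data shown here, none of the three values is a number, and no pair of measured compounds differs in a single place, so no measured step is available to guide an expectation.

Compound 4 `Clc1ccccc1-c1ccccc1-c1ccn2ncnc2n1` is the next compound. It differs from compound 2 by 2-chlorophenyl in place of chloro on an aromatic carbon. With compound 2 sitting at a limit and nothing measured on a comparable change, the expected step is a number no higher from compound 2 to compound 4 (the limit leaves the size open), none beyond the usual scatter. Compound 4 is thus expected to give about 100000 nM, within a range from 30000 nM to 300000 nM, most likely reported again as a limit.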

Compound 4, half-maximal inhibitory concentration: > 100000 nM
Compound 4 ended at the assay's limit; the forecaster's own chance of this, stated with the estimate: 70%; the middle value lies on the limit itself.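

Compound 2 and compound 4 both end at a limit of the assay and not at a number, so no step between them can be read: the limit of > 100000 nM in this assay, at which 3 of the 4 values shown sit.

The compounds shown leave open how strong the inhibition by either compound is, and whether 2-chlorophenyl in place of chloro on an aromatic carbon changes it at all.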